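The compounds below may be only part of what the source reports. "The series", "measured", "known", "first", "only" and "open" are said of these compounds alone.

Compound 1, `COc1cc(O)c(C(=O)/C=C/c2ccc(OCc3cn(-c4ccc(F)cc4Cl)nn3)c(OCc3cn(-c4ccc(F)cc4Cl)nn3)c2)c(OC)c1`, gives > 100 ug/mL in an ADME assay on Huh-7 cells (Homo sapiens) for cytotoxicity, read by MTT assay, with a stated time of 72 h (on this read-out lower numbers stand for higher toxicity in this test and higher numbers for lower toxicity in this test), and this value is a limit of the test, not a number.
Compound 2, `COc1cc(O)c(C(=O)/C=C/c2ccc(OCc3cn(-c4ccc(Cl)cc4)nn3)c(OCc3cn(-c4ccc(Cl)cc4)nn3)c2)c(OC)c1`, gives > 100 ug/mL, again a limit.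
Compound 3, `COc1cc(O)c(C(=O)/C=C/c2ccc(OCc3cn(-c4ccc(F)cc4Cl)nn3)c(OC)c2)c(OC)c1`, gives > 100 ug/mL, also a limit.

None of the three compounds shows a measurable toxicity in this assay: each stands at the limit of > 100 ug/mL in this assay, at which 3 of the 3 values shown sit, so the read-out only says that the true concentration lies beyond what the test covered. Among the compounds with values here, compound 3 therefore does not stand higher or lower than compound 1 or compound 2; all three are simply at the same limit, and no step between measured compounds can be given.

Compound 4, `COc1cc(O)c(C(=O)/C=C/c2ccc(OCc3cn(-c4ccccc4Cl)nn3)c(OC)c2)c(OC)c1`, has not yet been measured in this assay. It differs from compound 3 in one place: hydrogen in place of fluoro on an aromatic carbon.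

With every measured value sitting at the limit, no trend in either direction is visible, so the expectation is that the change from compound 3 to compound 4 produces no step beyond the usual scatter, an estimated step that the limit leaves unreadable from compound 3 to compound 4. Compound 4 is expected to give about 120 ug/mL, most likely reported again as a limit, with a range from 50 ug/mL to 300 ug/mL.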

Compound 4, half-maximal cytotoxic concentration: > 100 ug/mL
Compound 4: a limit, no number; the forecaster's own chance of this, stated with the estimate: 80%; the middle value does not contradict the limit.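

In this assay compound 4 gives > 100 ug/mL, which is a limit and not a number. No step from compound 3 to compound 4 can therefore be read, as both stand at the same limit: the limit of > 100 ug/mL in this assay, at which 4 of the 4 values shown sit.

The compounds shown leave open whether going from 2-chloro-4-fluorophenyl to 2-chlorophenyl changes toxicity at all, and at what concentration any of them becomes toxic.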